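This account rests on a few compounds, and the source may have more. Where it says the series, first, only, none or still open, it means among the compounds named here.

Working notes on the series. Compound 1 `O=c1cc(CSc2nc3ccccc3c(=O)[nH]2)c2ccc(OS(=O)(=O)c3ccccc3)cc2o1` gives 178000 nM in an ADME assay on Vero cells (Chlorocebus sabaeus) for cytotoxicity, read by polymerase chain reaction, with a stated time of 18 h; a higher number here means that more compound is tolerated, a lower number that less compound is tolerated. Compound 2 `O=c1cc(CSc2nc3ccccc3c(=O)[nH]2)c2ccc(OS(=O)(=O)c3ccc(F)cc3)cc2o1` gives 30000 nM in this assay, and compound 3 `Cc1ccc2nc(SCc3cc(=O)oc4cc(OS(=O)(=O)c5ccccc5)ccc34)[nH]c(=O)c2c1` gives 126000 nM. Compound 3 thus stands second highest of the three numbers: its nearest neighbour is compound 1, a gap within the scatter, and its furthest is compound 2, a gap beyond the scatter. The two single-place steps measured so far are a 5.9-fold lower number from compound 1 to compound 2 (0.77 log units; beyond the scatter) and a 1.4-fold lower number from compound 1 to compound 3 (0.15 log units; within the scatter).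

Compound 4 `Cc1ccc2nc(SCc3cc(=O)oc4cc(OS(=O)(=O)c5ccccc5[N+](=O)[O-])ccc34)[nH]c(=O)c2c1` differs from compound 3 by nitro in place of hydrogen on an aromatic carbon. Going by the values given here, the one measured step that bears on this change is a 5.9-fold lower number from compound 1 to compound 2 (0.77 log units; beyond the scatter), since it likewise adds a group to the phenylsulfonyl part; the step of a 1.4-fold lower number from compound 1 to compound 3 (0.15 log units; within the scatter) concerns the other ring and stayed within the scatter. On that basis compound 4 is expected to give a lower number than compound 3 in this assay, a step of about a 2.5-fold lower number from compound 3 to compound 4 (0.40 log units; beyond the scatter). The estimate for compound 4 in this assay is 50000 nM, with a range from 15000 nM to 150000 nM.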

Compound 4, half-maximal cytotoxic concentration: 107000 nM
Estimate against measurement, compound 4: 2.1-fold (0.33 log units) below; low and high end bracket the measured number.
By their numbers in this assay, from the lowest: compound 2; then compounds 4, 3 and 1 (each within the scatter of the next).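

In this assay, going from phenylsulfonyl to (2-nitrophenyl)sulfonyl, with nitro ortho to a large group, leaves the number within the scatter (a 1.2-fold lower number from compound 3 to compound 4 (0.07 log units; within the scatter)). Going by these compounds alone, this is the first sign that a group added to the phenylsulfonyl part does not always bring a step beyond the scatter, as the fluoro step did (a 5.9-fold lower number from compound 1 to compound 2 (0.77 log units; beyond the scatter)); those two steps differ in the group, may differ in its place, and start from different compounds, so they do not separate these factors. No measurement shown explains the result. As far as these compounds go, whether an amine or a carboxylic acid at this same place would also stay within the scatter remains open. Also open, from the compounds shown here alone, is whether nitro at this place gives a similar step on the core of compound 1, which carries hydrogen instead of the methyl of compound 3.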